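From hydroxy to dichloro: a step without direct precedent

The compounds below may be only part of what the source reports. "The series", "measured", "known", "first", "only" and "open" are said of these compounds alone.

Of the compounds shown here, three built on one shared core have been measured in a functional assay on NCI-H322M cells (Homo sapiens) for inhibition, read by sulforhodamine B assay, with a stated time of 48 h; on this read-out lower numbers stand for stronger inhibition of growth and higher numbers for weaker inhibition of growth. Compound 1 `O=C(Cc1csc2nc(-c3ccc(Br)cc3)cn12)N/N=C/c1ccccc1` gives 93300 nM, compound 2 `O=C(Cc1csc2nc(-c3ccc(Br)cc3)cn12)N/N=C/c1ccccc1O` gives 10700 nM and compound 3 `O=C(Cc1csc2nc(-c3ccc(Br)cc3)cn12)N/N=C/c1ccc(O)cc1` gives 34700 nM. Compound 3 therefore sits in the middle of the three, with a lower number than compound 1 and a higher one than compound 2.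

Compound 4 `O=C(Cc1csc2nc(-c3ccc(Br)cc3)cn12)N/N=C/c1ccc(Cl)cc1Cl` has not yet been measured. It differs from compound 3 in one place, where 2,4-dichlorophenyl stands in place of 4-hydroxyphenyl on a carbon with a double bond to nitrogen (2,4-dichlorophenyl in place of 4-hydroxyphenyl on a carbon with a double bond to nitrogen).

Within the data shown here, no measured compound carries chlorine, so no measured step speaks to this change directly. The closest evidence concerns the hydroxy group that is lost. Adding a hydroxy gave a 2.7-fold lower number from compound 1 to compound 3 (0.43 log units; beyond the scatter) and, at the other placement, an 8.7-fold lower number from compound 1 to compound 2 (0.94 log units; beyond the scatter), while moving it gave a 3.2-fold higher number from compound 2 to compound 3 (0.51 log units; beyond the scatter). All three steps are modest.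

Losing the hydroxy might drift the number back toward that of compound 1, at 93300 nM, but the effect of chlorine is unknown. The expected change is therefore small, a 1.2-fold higher number from compound 3 to compound 4 (0.06 log units; within the scatter) in this assay, within the scatter. For compound 4 the estimated value is 40000 nM, with an expected range from 12000 nM to 110000 nM.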

Compound 4, concentration for total growth inhibition: 69200 nM
The estimate for compound 4 lay 1.7-fold (0.24 log units) below the measured number, within the range that was stated.
By their numbers in this assay, from the lowest: compound 2; then compounds 3, 4 and 1 (each within the scatter of the next, the first and the last beyond it).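

Among these compounds, two chlorines on the phenyl ring do not reproduce the gain seen with the hydroxy group of compound 2 in this assay (a 6.5-fold higher number from compound 2 to compound 4 (0.81 log units; beyond the scatter)), so at this position the 2-hydroxyphenyl of compound 2 remains the one group with the lowest number, beyond the scatter of all three others. The 2,4-dichlorophenyl of compound 4 cannot be told apart from the 4-hydroxyphenyl of compound 3 (a 2.0-fold higher number from compound 3 to compound 4 (0.30 log units; within the scatter)) or from the unsubstituted phenyl of compound 1 (a 1.3-fold lower number from compound 1 to compound 4 (0.13 log units; within the scatter)), even though compounds 1 and 3 are separated beyond the scatter, which leaves compound 4 unresolved between them. No supporting measurement is available that would explain why these groups compare as they do.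

Compound 4 carries both chlorines at once, so the contribution of each cannot be separated, and a phenyl ring with a single chlorine would be needed to tell them apart. As far as these compounds go, whether a methoxy or an amino group in the place of the hydroxy of compound 2 would keep its lower number also remains open.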